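A few compounds are considered here, and "the series" means these few. Any claim that something is new, unique, unknown or untested is made for them only; others in the source may bear on it.

Measured compounds:
Compound 1, `COc1cc(CCc2ccc(Br)cc2)cc(OC)c1O`: 8490 nM
Compound 2, `COc1cc(CCc2cccc(F)c2)cc(OC)c1O`: 12400 nM
Compound 3, `COc1cc(CCc2ccccn2)cc(OC)c1O`: 4840 nM

All three numbers come from a functional assay on HepG2 cells (Homo sapiens) for antiproliferative activity, read by MTT assay, with a stated time of 72 h; on this read-out lower numbers stand for stronger inhibition and higher numbers for weaker inhibition. In this assay compound 1 gives 8490 nM, the middle one of the three numbers. Its gap to compound 2 and its gap to compound 3 both fall within the usual scatter of repeated measurements, so the three compounds cannot be told apart on these values.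

The unmeasured compound 4, `COc1cc(CCc2ccc(Cl)cc2)cc(OC)c1O`, keeps the shared core of compound 1 and differs in one place only: chloro in place of bromo on an aromatic carbon. Going by the values given here, with no measured pair in the set that shows what such a change does, the expectation rests on compound 1 alone and on the small size of the change in atom count, donor count and acceptor count. The step expected is a 1.1-fold lower number from compound 1 to compound 4 (0.03 log units; within the scatter), a change no larger than the scatter, in no particular direction. In this assay compound 4 is therefore estimated at 8000 nM, with a range from 4000 nM to 16000 nM.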

Compound 4, half-maximal inhibitory concentration: 8780 nM
The estimate for compound 4 lay 1.1-fold (0.04 log units) below the measured number; low and high end bracket the measured number.
By their numbers in this assay, from the lowest: compounds 3, 1, 4 and 2 (each within the scatter of the next, the first and the last beyond it).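

In this assay, chloro in place of bromo on an aromatic carbon, para to a large group, gives a 1.0-fold higher number from compound 1 to compound 4 (0.01 log units; within the scatter). This is the first pair among the compounds shown that differs in one place only, so it offers the first direct reading of a change at this position: on this read-out, the two halogens cannot be told apart. No supporting measurement is available to explain this result.

The pair speaks only for these two halogens at this one place on the ring, and a single step cannot show how far the finding extends. From the compounds shown here alone, whether an amine, a carboxylic acid or a longer alkyl chain in that place would move the number stays open, as does the effect of a plain hydrogen there.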